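This account rests on a few compounds, and the source may have more. Where it says the series, first, only, none or still open, it means among the compounds named here.

Compound 1, `CC(C)(C)Cc1csc(N)c1C(=O)c1ccc(Cl)cc1`, is the parent of this small set. In an assay on CHO cells for displacement of a labelled ligand from adenosine receptor A1 (Homo sapiens), read by scintillation counting, tested at 10 uM (a lower number here means less inhibition, a higher number more inhibition at the concentration tested (going by the name of the read-out)), compound 1 gives 1%. Compound 2, `CC(C)(C)Cc1c(Br)sc(N)c1C(=O)c1ccc(Cl)cc1`, carries a bromo group on the five-membered ring; in this assay compound 2 gives 1%. The one measured step, no change at the digits printed from compound 1 to compound 2 (within the scatter), thus stays within the scatter, and compound 2 stands level with compound 1 at the digits shown.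

Compound 3, `CC(C)(C)Cc1c(-c2ccco2)sc(N)c1C(=O)c1ccc(Cl)cc1`, is the next compound. Its difference from compound 2 is furan-2-yl in place of bromo on an aromatic carbon.

Among the compounds with values here, no measured step bears directly on exchanging bromo for furan-2-yl at this ring carbon. Within the data shown here, the only step known, no change at the digits printed from compound 1 to compound 2 (within the scatter), shows that adding a substituent at this position left the read-out unchanged, and both measured compounds sit near the bottom of the scale. On that basis compound 3 is expected to remain at a low level, with a step of a number 4 percentage points higher from compound 2 to compound 3 (within the scatter) that is expected to stay within the scatter. The estimate for compound 3 in this assay is 5%, expected to fall between 0% and 25%.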

Compound 3, a percentage reported as inhibition, at one concentration (the size of the read-out at that concentration, not a potency): 1%
Beside the measured number, compound 3's estimate is 4 percentage points above it, and the stated range covers the measured number.
By their numbers in this assay, from the lowest: compounds 1, 2 and 3 (each within the scatter of the next).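

In this assay the read-out shows no change at the digits printed from compound 2 to compound 3 (within the scatter) when furan-2-yl replaces bromo, and no change at the digits printed from compound 1 to compound 3 (within the scatter) when the same group replaces hydrogen on this aromatic carbon. Until now this position had only been tested with a single bromine atom, whereas compound 3 shows that a whole five-membered aromatic ring with one hydrogen-bond acceptor, placed next to the ring sulfur, also leaves the reading where the hydrogen of compound 1 had it. The set gives no explanation for why three such different substituents read alike.

Going by these compounds, all three compounds sit near the bottom of the scale, so it remains open whether any group on this carbon, such as a primary amine, a carboxylic acid or a longer alkyl chain, would give a clearly higher reading in this assay at all. On these data alone, it is equally open whether this position would respond differently on a core in which the neighbouring neopentyl group is replaced by something else, such as a benzyl group.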